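Isopropyl to methyl: a repeated change in cytotoxicity

The compounds below may be only part of what the source reports. "The series", "measured", "known", "first", "only" and "open" are said of these compounds alone.

Compound 2 `CC(C)/C(=N/c1ccnc2cc(Cl)ccc12)NCCCCN1CCCCC1` gives 5.72 ug/mL in an ADME assay on HepG2 cells (Homo sapiens) for cytotoxicity, read by MTT assay, with a stated time of 48 h; on this read-out higher numbers stand for weaker inhibition and lower numbers for stronger inhibition. Compound 1 `C/C(=N/c1ccnc2cc(Cl)ccc12)NCCCCN1CCCCC1` gives 9.81 ug/mL in this assay; the change from compound 2 to compound 1 is methyl in place of isopropyl on a carbon with a double bond to nitrogen, and it made a 1.7-fold higher number from compound 2 to compound 1 (0.23 log units; within the scatter). Compound 3 `CCN(CC)CCCCN/C(=N\c1ccnc2cc(Cl)ccc12)C(C)C` gives 5.01 ug/mL in this assay; it differs from compound 2 by diethylamino in place of piperidin-1-yl on a saturated chain carbon, four bonds along the chain from an amine nitrogen, a step of a 1.1-fold lower number from compound 2 to compound 3 (0.06 log units; within the scatter). Compound 4 `CCN(CC)CCCCN/C(C)=N\c1ccnc2cc(Cl)ccc12` has not yet been measured. It differs from compound 3 by methyl in place of isopropyl on a carbon with a double bond to nitrogen. Within the data shown here, this is the same change as the one from compound 2 to compound 1, with the surroundings of the place identical, but made on the other core, the one compound 3 shares with compound 4. The step from compound 3 to compound 4 is therefore expected to be about a 1.7-fold higher number from compound 3 to compound 4 (0.23 log units; within the scatter), resting on a 1.7-fold higher number from compound 2 to compound 1 (0.23 log units; within the scatter). Compound 4 is estimated at 8.5 ug/mL, with a range from 4.5 ug/mL to 16 ug/mL.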

Compound 4, half-maximal inhibitory concentration: 2.68 ug/mL
Compound 4: middle estimate off by 3.2-fold (0.50 log units), on the high side; the measured number lies below the stated range.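

In this assay, methyl in place of isopropyl gave a 1.9-fold lower number from compound 3 to compound 4 (0.27 log units; within the scatter), and although each step alone lies within the scatter, the steps on the two cores point in opposite directions and the gap between them does not lie within it: the same change on two cores in this assay, a 1.7-fold higher number (0.23 log units; within the scatter) from compound 2 to compound 1 and a 1.9-fold lower number (0.27 log units; within the scatter) from compound 3 to compound 4, 3.2-fold (0.51 log units) apart, beyond the scatter of two such steps Diethylamino in place of piperidin-1-yl also behaved differently, giving a 3.7-fold lower number from compound 1 to compound 4 (0.56 log units; beyond the scatter) when methyl is present, unlike the step with isopropyl present: the same change on two cores in this assay, a 1.1-fold lower number (0.06 log units; within the scatter) from compound 2 to compound 3 and a 3.7-fold lower number (0.56 log units; beyond the scatter) from compound 1 to compound 4, 3.2-fold (0.51 log units) apart, beyond the scatter of two such steps So a step measured on one core did not carry over reliably to the other here, but these few compounds do not show why, or how general this is.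

On these data alone, whether an ethyl group would follow methyl or isopropyl remains open. So does the behaviour of a different chain-end amine, such as morpholin-4-yl.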